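This account rests on a few compounds, and the source may have more. Where it says the series, first, only, none or still open, it means among the compounds named here.

Compound 1, `O=C(O)c1cc(-c2cocn2)ccc1O`: 110 mg/kg
Compound 2, `O=C(O)c1cc(-c2ccns2)ccc1O`: 80 mg/kg
Compound 3, `O=C(O)c1cc(-c2cscn2)ccc1O`: 95 mg/kg

In a functional assay on the whole organism for inhibition, with Rattus norvegicus as the target, read by paw edema (a lower number here means that less compound is needed, a higher number that more compound is needed for the effect), compound 1 shows the highest of the three numbers, yet its gaps to the other two stay within the scatter: a 1.2-fold lower number from compound 1 to compound 3 (0.06 log units; within the scatter) and a 1.4-fold lower number from compound 1 to compound 2 (0.14 log units; within the scatter). Compound 4, `O=C(O)c1cc(-c2nccs2)ccc1O`, has not been measured; it differs from compound 1 in one place: 1,3-thiazol-2-yl in place of 1,3-oxazol-4-yl on an aromatic carbon. Among the compounds with values here, the steps that bear on this swap of one five-membered ring for another are the two from compound 1 just named, together with a 1.2-fold higher number from compound 2 to compound 3 (0.07 log units; within the scatter), and none of them left the scatter. No step beyond the scatter is therefore expected in this assay. Compound 4 is expected to give 100 mg/kg, with a range from 60 mg/kg to 170 mg/kg, which means an estimated 1.1-fold lower number from compound 1 to compound 4 (0.04 log units; within the scatter).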

Compound 4, dose for half-maximal effect: > 250 mg/kg
Compound 4: only a limit was reported; the forecaster's own chance of this, stated with the estimate: 5%; at least 2.5-fold (0.39 log units) between middle value and limit.
By their numbers in this assay, from the lowest: compounds 2, 3 and 1 (each within the scatter of the next). At a limit, above all of these: compound 4.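

In this assay, the place para to a hydroxy group and meta to a carboxy group does not treat all five-membered aromatic rings alike: 1,3-thiazol-2-yl gives an at least 2.2-fold higher number from compound 1 to compound 4 (0.35 log units; beyond the scatter), an at least 2.6-fold higher number from compound 3 to compound 4 (0.42 log units; beyond the scatter) and an at least 3.1-fold higher number from compound 2 to compound 4 (0.49 log units; beyond the scatter). Even the same thiazole ring, joined through a different ring carbon in compound 3, falls on the other side of this gap. Compound 4 stands at a limit, not a number: the limit of > 250 mg/kg in this assay, at which 1 of the 4 values shown sits.

Going by these compounds, how far compound 4 lies past that limit stays open. So does the effect at this place of a non-ring group such as an amine or a longer chain.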